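Fluorophenyl triazole analogues on two terpenoid cores

The source may report more compounds than this note shows. Statements on the series, on what has been measured and on what is new or still open speak of the compounds shown alone.

Measured so far in a functional assay on SMMC-7721 cells (Homo sapiens) for cytotoxicity, read by MTT assay, with a stated time of 4 days; a lower number here means a stronger inhibitor, a higher number a weaker inhibitor:
- compound 1 `Cc1c(O)ccc2c1[C@H](Cn1cc(-c3ccccc3)nn1)[C@@]13CC(=O)[C@@](C)(CC[C@@H]21)C3`, a limit of the assay: > 20000 nM
- compound 2 `Cc1c(O)ccc2c1[C@H](Cn1cc(-c3ccc(F)cc3)nn1)[C@@]13CC(=O)[C@@](C)(CC[C@@H]21)C3`, likewise only a limit: > 20000 nM
- compound 3 `C=C1C[C@]23C[C@@]1(O)CC[C@@H]2c1cccc(C)c1[C@@H]3Cn1cc(-c2ccccc2)nn1`, again only a limit: > 20000 nM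

All three sit at the limit of > 20000 nM in this assay, at which 3 of the 3 values shown sit. The change from compound 1 to compound 2 is fluoro in place of hydrogen on an aromatic carbon, and its step, a step that the two limits leave unreadable from compound 1 to compound 2, cannot be read because the limit of > 20000 nM in this assay, at which 3 of the 3 values shown sit, caps both values. The difference between the two cores of compound 1 and compound 3 is not broken down here. Compound 4 `C=C1C[C@]23C[C@@]1(O)CC[C@@H]2c1cccc(C)c1[C@@H]3Cn1cc(-c2ccc(F)cc2)nn1`, not yet measured, repeats the same change on the core of compound 3: fluoro in place of hydrogen on an aromatic carbon, with the place described identically.

Going by the values given here, with compound 3 already at the limit and the only precedent unreadable, compound 4 is expected to give 30000 nM in this assay, most likely reported only as a limit. The step from compound 3 to compound 4 is estimated as a step that the limit leaves unreadable from compound 3 to compound 4, resting on nothing beyond (the limit of > 20000 nM in this assay, at which 3 of the 3 values shown sit).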

Compound 4, half-maximal inhibitory concentration: > 20000 nM
Compound 4: no number, only a limit; the forecaster's own chance of this, stated with the estimate: 85%; the middle value is on the limit's open side.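

Going by these compounds alone, compound 4 gives > 20000 nM, a limit and not a number; compound 3 is also only a limit, so no step from compound 3 to compound 4 can be read. As far as these compounds go, the effect of phenyl to 4-fluorophenyl on either core remains open.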